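The compounds below may be only part of what the source reports. "The series", "measured", "known", "first", "only" and "open" are said of these compounds alone.

Compound 1 `Cn1c(=O)c(=O)n(C2CCCC2)c2nc(N/N=C/c3ccc(O)cc3)ncc21` carries a 4-hydroxyphenyl on the carbon with a double bond to nitrogen. In a functional assay on PC-3 cells (Homo sapiens) for antiproliferative activity, read by MTT assay (on this read-out lower numbers stand for stronger inhibition and higher numbers for weaker inhibition), compound 1 gives only a limit, > 100000 nM, and not a number (the limit of > 100000 nM in this assay, at which 1 of the 3 values shown sits). Compound 2 `Cc1cccc(/C=N/Nc2ncc3c(n2)n(C2CCCC2)c(=O)c(=O)n3C)c1` gives 53600 nM in this assay, and compound 3 `COc1cccc(/C=N/Nc2ncc3c(n2)n(C2CCCC2)c(=O)c(=O)n3C)c1` gives 20700 nM. The step of an at least 1.8-fold lower number from compound 1 to compound 2 (0.27 log units; that floor lies within the scatter) reaches only a floor that stays within the scatter, whereas an at least 4.8-fold lower number from compound 1 to compound 3 (0.68 log units; beyond the scatter) goes beyond it, and between the two measured partners there is a 2.6-fold lower number from compound 2 to compound 3 (0.41 log units; beyond the scatter).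

Compound 4 `Cn1c(=O)c(=O)n(C2CCCC2)c2nc(N/N=C/c3cccs3)ncc21` has not yet been measured. It differs from compound 1 in one place: thiophen-2-yl in place of 4-hydroxyphenyl on a carbon with a double bond to nitrogen. The two measured steps that start from compound 1 both exchange the 4-hydroxyphenyl for another aromatic ring, and both lower the number, one of them at least modestly. For the measured compounds named here, no measured step puts a thiophen-2-yl on that carbon, so the size of the step for compound 4 can rest only on those two exchanges. The account therefore expects a lower number than the limit of compound 1, of modest size, expressed as an at least 2.5-fold lower number from compound 1 to compound 4 (0.39 log units; beyond the scatter). In this assay compound 4 is expected to give 40000 nM, with a range from 15000 nM to 110000 nM.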

Compound 4, half-maximal inhibitory concentration: 75600 nM
Compound 4: middle estimate off by 1.9-fold (0.28 log units), on the low side, and the stated range covers the measured number.
By their numbers in this assay, from the lowest: compound 3; then compounds 2 and 4 (each within the scatter of the next). At a limit, above all of these: compound 1.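

In this assay, the thiophen-2-yl is the only five-membered aromatic ring with a hetero atom shown on the carbon with a double bond to nitrogen, and its exchange for the 4-hydroxyphenyl gives an at least 1.3-fold lower number from compound 1 to compound 4 (0.12 log units; that floor lies within the scatter), so this change does not establish any gain over compound 1. That comparison remains a floor and no more: the limit of > 100000 nM in this assay, at which 1 of the 4 values shown sits. The measured partners say more: a 3.7-fold higher number from compound 3 to compound 4 (0.56 log units; beyond the scatter) shows that the 3-methoxyphenyl and the thiophen-2-yl are distinguishable at this position, whereas a 1.4-fold higher number from compound 2 to compound 4 (0.15 log units; within the scatter) leaves the 3-methylphenyl and the thiophen-2-yl unresolved, so replacing the six-membered ring with the five-membered one does not have a single reading across these compounds.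

The compounds shown leave open whether a 4-methoxyphenyl on that carbon would behave like the 3-methoxyphenyl, and whether a furan-2-yl or a pyridin-2-yl would read like the thiophen-2-yl. They also leave open what an amine or a carboxylic acid on the aromatic ring would do to the number in this assay.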